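A few compounds are considered here, and "the series" means these few. Any claim that something is new, unique, unknown or untested is made for them only; others in the source may bear on it.

Working notes on the amide series. The three measured compounds share one core and differ only in the amide substituent: compound 1 `CCN(CC)CCNC(=O)c1ccc(C(CC)(CC)c2ccc(OCC(O)C(C)(C)C)c(C)c2)n1CC`, compound 2 `CCn1c(C(=O)NCCCN(C)C)ccc1C(CC)(CC)c1ccc(OCC(O)C(C)(C)C)c(C)c1` and compound 3 `CCn1c(C(=O)NCC(OC)OC)ccc1C(CC)(CC)c1ccc(OCC(O)C(C)(C)C)c(C)c1`. In an assay on HL-60 cells for agonist activity at vitamin D3 receptor (Homo sapiens), read by microscopy, with a stated time of 96 h (on this read-out higher numbers stand for an effect only at larger amounts of compound and lower numbers for an effect already at smaller amounts), compound 1 gives 110 nM, compound 2 gives 37 nM and compound 3 gives 150 nM. Compound 3 thus carries the highest of the three numbers; its gap to compound 1 stays within the scatter, while the step of a 4.1-fold higher number from compound 2 to compound 3 (0.61 log units; beyond the scatter) lies beyond it.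

The next compound, compound 4 `CCn1c(C(=O)N(C)CCC#N)ccc1C(CC)(CC)c1ccc(OCC(O)C(C)(C)C)c(C)c1`, is built from compound 3 by the change ((2-cyanoethyl)(methyl)amino in place of (2,2-dimethoxyethyl)amino on a carbonyl carbon). Among the measured compounds shown here, two measured steps touch the same amide substituent: a 1.4-fold higher number from compound 1 to compound 3 (0.13 log units; within the scatter), which is within the scatter, and a 4.1-fold higher number from compound 2 to compound 3 (0.61 log units; beyond the scatter), which is modest and beyond it. For the measured compounds named here, neither of them removes the amide hydrogen or brings in a nitrile, so no measured step matches the present change directly; only compound 2, with its dimethylamino chain, moved the number clearly. On that basis the step from compound 3 to compound 4 is expected to be small, no change at the digits printed from compound 3 to compound 4 (within the scatter), with no direction beyond the scatter. For compound 4 the estimate in this assay is 150 nM, with a range from 60 nM to 400 nM.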

Compound 4, half-maximal effective concentration: 1960 nM
For compound 4 the middle estimate is 13-fold (1.12 log units) below the measured one, outside the stated range (above it).
By their numbers in this assay, from the lowest: compound 2; then compounds 1 and 3 (each within the scatter of the next); then compound 4.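

In this assay the amide substituent proves able to move the number much further than the first three compounds showed: the (2-cyanoethyl)(methyl)amino group gives a 13-fold higher number from compound 3 to compound 4 (1.12 log units; beyond the scatter) and an 18-fold higher number from compound 1 to compound 4 (1.25 log units; beyond the scatter) and a 53-fold higher number from compound 2 to compound 4 (1.72 log units; beyond the scatter) with all three steps large, whereas no earlier step among these substituents went beyond modest. Among the compounds shown here, compound 4 is also the only compound here with no amide hydrogen and the only one with a nitrile, and it stands clearly apart from the three compounds that keep that hydrogen, whether their chains end in an amine or in the dimethoxymethyl group. No measurement at hand bears on what lies behind this rise, so the result stays a description of the change as a whole.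

The compounds shown leave the two parts of the change unseparated: a (2-cyanoethyl)amino group would keep the nitrile with the amide hydrogen, and a (3-(dimethylamino)propyl)(methyl)amino group would remove that hydrogen while keeping the amine chain. Also open, going by these compounds, is how a carboxylic acid or a morpholine at the chain end would read against compound 2 at 37 nM in this assay on the same core.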